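This account rests on a few compounds, and the source may have more. Where it says the series, first, only, none or still open, it means among the compounds named here.

Compound 1 `CC(C)OC(=O)C1=CN(C(=O)c2cccs2)CC(C)(C)c2cc(C#N)[nH]c21`: 16 nM in an assay on HEK293 cells for agonist activity at Bile acid receptor (Homo sapiens), read by a luciferase reporter; a lower number here means that less compound is needed, a higher number that more compound is needed for the effect.
Compound 2 `CC(C)OC(=O)C1CN(C(=O)c2ccc(C#N)cc2)CC(C)(C)c2cc(C#N)[nH]c21`: 5700 nM in this assay.

Compound 1 stands lowest of the two numbers; compound 2 gives a far higher number, a gap beyond the usual scatter, but the two structures differ in several places, so only their values can be set side by side. Compound 3 `CC(C)OC(=O)C1=CN(C(=O)C2CCCCC2)CC(C)(C)c2cc(C#N)[nH]c21` has not yet been measured. It differs from compound 1 by cyclohexyl in place of thiophen-2-yl on a carbonyl carbon. For the measured compounds named here, no measured pair shows a change of this kind, so compound 3 is expected to stay close to compound 1, with a 2.5-fold higher number from compound 1 to compound 3 (0.40 log units; beyond the scatter) expected to be a modest rise at most. For compound 3 the estimate in this assay is 40 nM, ranging from 10 nM to 200 nM.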

Compound 3, half-maximal effective concentration: 6.5 nM
Beside the measured number, compound 3's estimate is 6.2-fold (0.79 log units) above it, and the stated range ends above it.
By their numbers in this assay, from the lowest: compound 3; then compound 1; then compound 2.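

In this assay, the carbonyl carbon on the amide-type ring nitrogen accepts a non-aromatic ring of carbon only: cyclohexyl in place of thiophen-2-yl gives a 2.5-fold lower number from compound 1 to compound 3 (0.39 log units; beyond the scatter) and so does not raise the number. For this pair, then, the five-membered aromatic ring with its sulfur is not needed for a low number. Nothing available explains the step.

The compounds shown leave open how a phenyl ring, a piperidine ring or an open chain such as n-butyl would fare on this carbonyl carbon.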